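The source may hold more compounds than are shown below. What is called first, only, known or untested is meant among the compounds shown, and "the series" means these compounds.

Two compounds of the series carry numbers in a functional assay on MDA-MB-231 cells (Homo sapiens) for cytotoxicity, read by sulforhodamine B assay, with a stated time of 3 days; on this read-out higher numbers stand for weaker inhibition and lower numbers for stronger inhibition. Compound 1 `Nc1ccccc1S(=O)(=O)N1CC(n2cnc3c(Cl)nc(Cl)nc32)OCc2ccccc21` gives 467 nM in this assay. Compound 2 `O=[N+]([O-])c1ccccc1S(=O)(=O)N1CC(n2cnc3c(Cl)nc(Cl)nc32)OCc2ccccc21` gives 280 nM in this assay. Exchanging the nitro for the amino on an aromatic carbon produces a 1.7-fold lower number from compound 1 to compound 2 (0.22 log units; within the scatter). Compound 2 therefore holds the lowest of the two numbers, with compound 1 the nearest; the gap is within the scatter, so neither compound can be ranked above the other.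

Compound 3 `O=[N+]([O-])c1ccccc1S(=O)(=O)N1CC(n2cnc3nc(Cl)nc(Cl)c32)OCc2ccccc21` differs from compound 2 in another way: a group of 11 heavy atoms (5 carbon, 4 nitrogen, 2 chlorine; one five-membered aromatic ring with 2 hetero atoms, one six-membered aromatic ring with 2 hetero atoms) in place of a group of 11 heavy atoms (5 carbon, 4 nitrogen, 2 chlorine; one five-membered aromatic ring with 2 hetero atoms, one six-membered aromatic ring with 2 hetero atoms), on a saturated ring carbon. The two compounds contain the same atoms joined differently, and the change sits on a saturated ring carbon of the seven-membered non-aromatic ring of the shared core. Among the measured compounds shown here, no measured step touches this part of the molecule; the only step in hand, from compound 1 to compound 2, concerns a substituent on an aromatic carbon elsewhere and says nothing about the group on the saturated ring carbon. The expectation for compound 3 in this assay is accordingly a step of a 1.4-fold higher number from compound 2 to compound 3 (0.15 log units; within the scatter), that is, no change beyond the scatter. The range is kept wide; the rearranged group is the one bearing both chlorines. Compound 3 is estimated at 400 nM, between 150 nM and 1100 nM.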

Compound 3, half-maximal inhibitory concentration: 318 nM
Compound 3: the middle estimate sits 1.3-fold (0.10 log units) above what was measured; the measured number falls inside the stated range.
By their numbers in this assay, from the lowest: compounds 2, 3 and 1 (each within the scatter of the next).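

In this assay, exchanging one group for the other on the saturated ring carbon next to the ring oxygen gives a 1.1-fold higher number from compound 2 to compound 3 (0.06 log units; within the scatter). Among the compounds shown here, this is the first reading at this position, since the earlier step concerned only a substituent on an aromatic carbon: with the nitro in place, the two groups, built from the same atoms joined differently and both bearing two chlorines, cannot be told apart on this read-out. Nothing available on these compounds accounts for this outcome.

As far as these compounds go, the pair tests only a rearrangement of the group with the nitro present, so it remains open whether the two groups would also read alike with the amino on the aromatic carbon, as in compound 1. From the compounds shown here alone, it is equally open whether the number at this position depends on the chlorines themselves, a question that a group carrying an amine or a methoxy in place of one chlorine, or a group with hydrogen in place of both, would address in the same assay.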